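The source may report more compounds than this note shows. Statements on the series, on what has been measured and on what is new or still open speak of the compounds shown alone.

Measured in an ADME assay on EA.hy 926 cells (Homo sapiens) for inhibition, read by MTT assay, with a stated time of 72 h; a higher number here means a weaker inhibitor, a lower number a stronger inhibitor:
Compound 1 `CC(C)CNC(=C\C(=O)/C=C/c1ccc(O)cc1)/C=C/c1ccc(O)cc1`: > 25000 nM
Compound 2 `CC(=O)Oc1ccc(/C=C/C(=O)/C=C(/C=C/c2ccc(OC(C)=O)cc2)NCC(C)C)cc1`: > 25000 nM

Neither entry is a true number, since each is a limit of the assay. Compound 1 stands at > 25000 nM, which is a limit. Compound 2 shows > 25000 nM, also a limit. Within the data shown here, the record so far therefore holds only (the limit of > 25000 nM in this assay, at which 2 of the 2 values shown sit), and no measured step shows how much a structural change can matter.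

Compound 3 `O=C(/C=C(/C=C/c1ccc(O)cc1)NC1CCCCC1)/C=C/c1ccc(O)cc1` keeps the core of compound 1 but has cyclohexyl in place of isobutyl on an amine nitrogen. The entering group brings one six-membered non-aromatic ring of carbon only.

Among the measured compounds shown here, with no measured step to draw on, the expectation rests on compound 1 and its limit of > 25000 nM. The expected change, an at least 1.2-fold lower number from compound 1 to compound 3 (0.09 log units; that floor lies within the scatter), is small and towards a stronger inhibitor. A result at the same limit would be no surprise. Compound 3 is estimated at 20000 nM, with an expected range from 8000 nM to 50000 nM.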

Compound 3, half-maximal inhibitory concentration: 3300 nM
The estimate for compound 3 lay 6.1-fold (0.78 log units) above the measured number; the measured number lies below the stated range.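

In this assay, cyclohexyl in place of isobutyl on an amine nitrogen gives an at least 7.5-fold lower number from compound 1 to compound 3 (0.87 log units; beyond the scatter). This shows that the group on this nitrogen can make a clear difference on the core of compound 1, which the earlier pair, both sitting at the same limit, could not show. Going by these compounds, the true size of the step remains unknown because its starting point is a limit rather than a number: the limit of > 25000 nM in this assay, at which 2 of the 3 values shown sit.

The compounds shown cannot say whether the gain depends on the ring itself or simply on having more carbon atoms in the group, nor why either would matter. A straight hexyl chain or a cyclopentyl ring on the same nitrogen would help to separate these two readings.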